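Adding a carbon to the side chain of compound 2

This account rests on a few compounds, and the source may have more. Where it says the series, first, only, none or still open, it means among the compounds named here.

Two measured compounds share one core and carry a saturated chain on it. Compound 2 `CCCc1cc2ccccc2nc1-c1cc(-c2ccc(C(F)(F)F)cc2)no1` bears a propyl chain together with a trifluoromethylphenyl group; in a functional assay on PC-3 cells (Homo sapiens) for inhibition, read by MTT assay, with a stated time of 24 h (a higher number here means a weaker inhibitor, a lower number a stronger inhibitor), compound 2 gives 33800 nM. Compound 1 `CCCCc1cc2ccccc2nc1-c1cc(-c2ccccc2)no1` carries a butyl chain and an unsubstituted phenyl group. In this assay compound 1 reaches only > 100000 nM, which is a limit of the assay and not a number. Within the data shown here, compound 2 thus holds the only measured value shown, while one of the two results sits at the limit of > 100000 nM in this assay, at which 1 of the 2 values shown sits. Compound 3 `CCCCc1cc2ccccc2nc1-c1cc(-c2ccc(C(F)(F)F)cc2)no1` is the unmeasured partner of compound 2: the change is methyl in place of hydrogen on a saturated chain carbon, three bonds along the chain from an aromatic carbon, which read one bond further out is propyl to butyl. Among the measured compounds shown here, no step between two measured compounds is available to calibrate this change. A small step is expected, at most modestly toward weaker inhibition, and quite possibly none beyond the usual scatter. The step from compound 2 to compound 3 is estimated at a 1.3-fold higher number from compound 2 to compound 3 (0.12 log units; within the scatter). Compound 3 is expected to give about 45000 nM in this assay, within a range from 15000 nM to 150000 nM.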

Compound 3, half-maximal inhibitory concentration: 10800 nM
Beside the measured number, compound 3's estimate is 4.2-fold (0.62 log units) above it, outside the stated range (below it).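

In this assay, the longer chain did not leave the number unchanged or push it upward. Going from propyl to butyl on the compounds that carry trifluoromethyl gives a 3.1-fold lower number from compound 2 to compound 3 (0.50 log units; beyond the scatter), so methyl in place of hydrogen on this saturated chain carbon, three bonds along the chain from an aromatic carbon, moves the result beyond the scatter toward stronger inhibition. With the butyl chain held constant, the other change, trifluoromethyl in place of hydrogen on an aromatic carbon, gives an at least 9.2-fold lower number from compound 1 to compound 3 (0.96 log units; beyond the scatter), and the value of compound 1 in that step is a limit of the assay and not a number, so the size of this step is known only as a bound: the limit of > 100000 nM in this assay, at which 1 of the 3 values shown sits.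

One step along the chain does not make a trend, and the compounds shown leave open whether a pentyl chain or a still longer chain would lower the number further or raise it again. They also leave open what an amine or a carboxylic acid at the end of the chain would do, or how a methoxy group or a fluorine in place of trifluoromethyl would read in this same test.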